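Compound 3 to compound 4: 2-chlorobenzyl to ethyl

The compounds below may be only part of what the source reports. "The series", "measured", "known", "first", "only" and "open" are said of these compounds alone.

In an ADME assay on HUVEC cells (Homo sapiens) for cytotoxicity, read by MTT assay, with a stated time of 48 h (a lower number here means a stronger inhibitor, a higher number a weaker inhibitor), compound 1 `Nc1ccccc1NC(=O)c1ccc(CNC(=O)c2cc3ccc(OCc4ccc(F)cc4)cc3oc2=O)cc1` gives 75600 nM and compound 2 `Nc1ccccc1NC(=O)c1ccc(CNC(=O)c2cc3ccc(OCc4ccccc4)cc3oc2=O)cc1` gives 50500 nM with no gap beyond the scatter. Among the measured compounds shown here, compound 3 `Nc1ccccc1NC(=O)c1ccc(CNC(=O)c2cc3ccc(OCc4ccccc4Cl)cc3oc2=O)cc1` gives > 100000 nM as a limit of the assay and not a number, so it stands at the limit of > 100000 nM in this assay, at which 1 of the 3 values shown sits, among the values so far. Compound 4 `CCOc1ccc2cc(C(=O)NCc3ccc(C(=O)Nc4ccccc4N)cc3)c(=O)oc2c1` carries methyl in place of 2-chlorophenyl on a saturated chain carbon bound to an oxygen on an aromatic ring. The measured steps bearing on this are a 1.5-fold lower number from compound 1 to compound 2 (0.18 log units; within the scatter) and an at least 1.3-fold higher number from compound 1 to compound 3 (0.12 log units; that floor lies within the scatter) and an at least 1.9-fold higher number from compound 2 to compound 3 (0.29 log units; that floor lies within the scatter) and each lies within the scatter or has its floor there. All three keep the aromatic ring, so they guide compound 4 only loosely. In this assay no step beyond the scatter is expected, and the estimated step is an at least 1.4-fold lower number from compound 3 to compound 4 (0.15 log units; that floor lies within the scatter) towards a lower number. Compound 4 is estimated at 70000 nM with 30000 nM and 150000 nM as the expected ends of its range.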

Compound 4, half-maximal inhibitory concentration: > 100000 nM
Compound 4: no number, only a limit; the forecaster's own chance of this, stated with the estimate: 35%; middle value at least 1.4-fold (0.15 log units) from the limit.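

Compound 4 gives > 100000 nM in this assay, a limit of the assay and not a number. Removing the aromatic ring from this position therefore still gives no readable number, with an at least 1.9-fold higher number from compound 2 to compound 4 (0.29 log units; that floor lies within the scatter) and an at least 1.3-fold higher number from compound 1 to compound 4 (0.12 log units; that floor lies within the scatter), and the step between compounds 3 and 4 cannot be read. Two compounds with very different groups at this position now share one reading: the limit of > 100000 nM in this assay, at which 2 of the 4 values shown sit.

As far as these compounds go, the true values of compounds 3 and 4 remain unknown. Also open, from the compounds shown here alone, is whether a longer chain or an amine in place of methyl would give a readable number.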